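Replacing the (2-(methylsulfonyl)ethyl)amino group of compound 2

The source may report more compounds than this note shows. Statements on the series, on what has been measured and on what is new or still open speak of the compounds shown alone.

Compound 1 `Cc1c(C(=O)OCCCN(C)C)oc2ccc(N(Cc3ccc(Br)cc3)S(=O)(=O)c3ccc(Br)cc3)cc12`: 11200 nM
Compound 2 `Cc1c(C(=O)NCCS(C)(=O)=O)oc2ccc(N(Cc3ccc(Br)cc3)S(=O)(=O)c3ccc(Br)cc3)cc12`: > 40000 nM (a limit, not a number)

Both compounds were tested in a functional assay on HCT-116 cells (Homo sapiens) for antiproliferative activity, read by MTT assay, with a stated time of 48 h; a lower number here means a stronger inhibitor, a higher number a weaker inhibitor. Compound 2 gives no number there and sits at the limit of > 40000 nM in this assay, at which 1 of the 2 values shown sits.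

Compound 3 `Cc1c(C(=O)N2CCCC(C)C2)oc2ccc(N(Cc3ccc(Br)cc3)S(=O)(=O)c3ccc(Br)cc3)cc12` keeps the shared core and changes one group: 3-methylpiperidin-1-yl stands in place of (2-(methylsulfonyl)ethyl)amino on a carbonyl carbon (3-methylpiperidin-1-yl in place of (2-(methylsulfonyl)ethyl)amino on a carbonyl carbon).

Among the compounds with values here, one measured step bears on this change, as it concerns the same place: an at least 3.5-fold higher number from compound 1 to compound 2 (0.55 log units; beyond the scatter). As far as these compounds go, that step ends at a limit, so its full size is unknown. It is also a single step, and it involves a different incoming group, which makes it only a loose guide.

In this assay, compound 1 gives a measurable 11200 nM, so a number is expected to be reachable with another group at this place. A modest move towards a lower number is therefore expected, although compound 3 could also remain at the limit. The expected change is an at least 2.0-fold lower number from compound 2 to compound 3 (0.30 log units; that floor lies within the scatter). Compound 3 is estimated at 20000 nM, with an expected range from 8000 nM to 40000 nM.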

Compound 3, half-maximal inhibitory concentration: 23100 nM
Estimate against measurement, compound 3: 1.2-fold (0.06 log units) below; the range from low to high includes it.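

In this assay, compound 2 gives no number and stands only at a limit: the limit of > 40000 nM in this assay, at which 1 of the 3 values shown sits. As far as these compounds go, compound 3, with 3-methylpiperidin-1-yl on the carbonyl carbon, gives a measured value, which shows that a number at this place does not depend on the 3-(dimethylamino)propoxy group, and the change reads as an at least 1.7-fold lower number from compound 2 to compound 3 (0.23 log units; that floor lies within the scatter), so its full size stays unknown. The new group still does not reach the value given by 3-(dimethylamino)propoxy, as the comparison shows a 2.1-fold higher number from compound 1 to compound 3 (0.31 log units; beyond the scatter).

Compound 3 differs from compound 2 in several counted features at once, namely the ring, the hydrogen-bond donor and the hydrogen-bond acceptors, so the compounds shown cannot say which of these accounts for the change. They also leave open whether a morpholine, a piperazine or an unsubstituted piperidine on the carbonyl carbon would give a lower number than compound 1 does, and what the methyl group on the ring of compound 3 contributes.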